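Shortening the aryl ether and adding a nitrile in compound 4

The source may report more compounds than this note shows. Statements on the series, on what has been measured and on what is new or still open speak of the compounds shown alone.

Compound 1 `Cc1nn(-c2ncnc3nc[nH]c23)c2c1C(OCCc1ccccc1)CC(=O)N2` gives 40 nM in a functional assay on HEK293 cells for agonist activity at G-protein coupled receptor 39 (Homo sapiens), read by scintillation proximity assay and inositol phosphate accumulation, with a stated time of 75 min (a higher number here means that more compound is needed for the effect, a lower number that less compound is needed), the lowest number among the three measured compounds. Compound 2 `Cc1nn(-c2ncnc3nc[nH]c23)c2c1C(NC(=O)Cc1cccs1)CC(=O)N2` gives 244 nM, and compound 3 `Cc1nn(-c2ncnc3nc[nH]c23)c2c1C(OCCn1cccn1)CC(=O)N2` gives 2270 nM. Compound 4 `Cc1nn(-c2ncnc3nc[nH]c23)c2c1C(OCc1ccc(C#N)cc1)CC(=O)N2` differs from compound 1 by 4-cyanophenyl in place of benzyl on a saturated chain carbon bound to an oxygen on a saturated carbon. Among the measured compounds shown here, no measured step matches this change directly. The nearest guide is a 57-fold higher number from compound 1 to compound 3 (1.75 log units; beyond the scatter), which shows that replacing the aromatic ring at the end of this ether chain costs heavily, while a 6.1-fold higher number from compound 1 to compound 2 (0.79 log units; beyond the scatter) shows a modest loss when the side chain is altered closer to the core. Since the aromatic carbon ring is kept here, only a modest loss is expected for compound 4, as a 3.0-fold higher number from compound 1 to compound 4 (0.48 log units; beyond the scatter), with an estimated value of 120 nM and a range of 30 nM to 500 nM.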

Compound 4, half-maximal effective concentration: 60 nM
Estimate against measurement, compound 4: 2.0-fold (0.30 log units) above; measured number inside the range.
By their numbers in this assay, from the lowest: compounds 1 and 4 (each within the scatter of the next); then compound 2; then compound 3.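

In this assay, the step of a 1.5-fold higher number from compound 1 to compound 4 (0.18 log units; within the scatter) shows that (4-cyanobenzyl)oxy can take the place of phenethyloxy on this saturated ring carbon without a loss beyond the scatter. The same group compares well with the other side chains, through a 38-fold lower number from compound 3 to compound 4 (1.58 log units; beyond the scatter) and through a 4.1-fold lower number from compound 2 to compound 4 (0.61 log units; beyond the scatter). Nothing available gives a reason for these steps. As far as these compounds go, compound 4 combines the shorter chain and the nitrile in one change, so their separate contributions remain open. Also open, from the compounds shown here alone, is how an amine or a carboxylic acid in place of the nitrile would behave.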